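The compounds below may be only part of what the source reports. "The series", "measured", "known", "first", "only" and "open" are said of these compounds alone.

In a functional assay on HepG2 cells (Homo sapiens) for inhibition, read by MTT assay, with a stated time of 48 h (on this read-out lower numbers stand for stronger inhibition and higher numbers for weaker inhibition), compound 1, `COc1cc(-c2nnc(SCC(=O)c3ccc(F)cc3)n2-c2ccc(N(C)C)cc2)cc(OC)c1OC`, gives > 60000 nM, which is a limit of the assay and not a number. Compound 2, `CCOC(=O)CSc1nnc(-c2cc(OC)c(OC)c(OC)c2)n1-c1ccc(N(C)C)cc1`, gives > 60000 nM, again a limit and not a number, so compound 2 has no measured position, only a bound. The next compound, compound 3, `COc1ccc(NC(=O)CSc2nnc(-c3cc(OC)c(OC)c(OC)c3)n2-c2ccc(N(C)C)cc2)cc1`, carries (4-methoxyphenyl)amino in place of ethoxy on a carbonyl carbon, and the change counts as (4-methoxyphenyl)amino in place of ethoxy on a carbonyl carbon. For the measured compounds named here, only one measured step bears on this site, a step that the two limits leave unreadable from compound 1 to compound 2. It offers no size to carry forward, and the rest of the evidence is the limit of > 60000 nM in this assay, at which 2 of the 2 values shown sit. Neither the 4-fluorophenyl nor the ethoxy on that carbonyl carbon yielded a number, so the expectation for the new group is cautious. Another limit would be no surprise, and any number that does appear is expected close under the ceiling of this assay. The expected change is an at least 1.5-fold lower number from compound 2 to compound 3 (0.17 log units; that floor lies within the scatter), a modest estimated move toward stronger inhibition at best. For compound 3 the estimate is 40000 nM, with an expected range from 8000 nM to 60000 nM.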

Compound 3, half-maximal inhibitory concentration: > 60000 nM
Compound 3 gave a limit, no number; the forecaster's own chance of this, stated with the estimate: 65%; at least 1.5-fold (0.17 log units) between middle value and limit.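

Compound 3 gives a limit and not a number in this assay, so none of the steps among compound 1, compound 2 and compound 3 can be read: the limit of > 60000 nM in this assay, at which 3 of the 3 values shown sit. The compounds shown leave open whether any group on this carbonyl carbon would give a measurable value in this assay.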